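The source may hold more compounds than are shown below. What is called first, only, known or untested is meant among the compounds shown, and "the series" means these compounds.

Working notes on the series. Compound 2 `Cc1nn(C)c2nc(C3CC3)c(/C=C/[C@@H](O)C[C@@H](O)CC(=O)O)c(-c3ccc(F)cc3)c12` is the reference here; in an in vivo functional assay on the whole organism for inhibition of 3-hydroxy-3-methylglutaryl-coenzyme A reductase (Rattus norvegicus), at a dose of 2 mg/kg by the oral route (a lower number here means a weaker effect, a higher number a stronger effect of the compound at the dose given), compound 2 gives 74.3%, the highest of the three numbers recorded, though each of the other two lies within the scatter of it. Compound 1 `Cc1nn(C(C)(C)C)c2nc(C3CC3)c(/C=C/[C@@H](O)C[C@@H](O)CC(=O)O)c(-c3ccc(F)cc3)c12` gives 72.2% in this assay, and compound 3 `O=C(O)C[C@H](O)C[C@H](O)/C=C/c1c(C2CC2)nc2sccc2c1-c1ccc(F)cc1` gives 70.6%. Going by the values given here, the one single-point step available, a number 2.1 percentage points higher from compound 1 to compound 2 (within the scatter), concerns methyl in place of tert-butyl on an aromatic nitrogen and lies within the scatter. Compound 4 `Cn1nc(-c2ccccc2)c2c(-c3ccc(F)cc3)c(/C=C/[C@@H](O)C[C@@H](O)CC(=O)O)c(C3CC3)nc21` differs from compound 2 by phenyl in place of methyl on an aromatic carbon. Among the compounds with values here, no measured step alters a group on an aromatic carbon of that ring, so the only guide is that the sole recorded step is within the scatter; an estimated step of a number 4.3 percentage points lower from compound 2 to compound 4 (within the scatter) is therefore expected, none beyond the scatter. Compound 4 is estimated at 70%, with a range from 55% to 82%.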

Compound 4, a percentage reported as inhibition, in the whole organism at one dose (the size of the read-out at that dose, not a potency): 11.5%
Estimate against measurement, compound 4: 58.5 percentage points above, outside the stated range (below it).
By their numbers in this assay, from the lowest: compound 4; then compounds 3, 1 and 2 (each within the scatter of the next).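

This aromatic carbon of the five-membered ring is sensitive to its substituent in this assay: phenyl in place of methyl gives a number 62.8 percentage points lower from compound 2 to compound 4 (beyond the scatter), whereas the change on the aromatic nitrogen, a number 2.1 percentage points higher from compound 1 to compound 2 (within the scatter), stays within the scatter. This is the first single-place change shown that moves the read-out beyond the scatter. Nothing available accounts for the loss.

The compounds shown leave open whether the loss follows from the aromatic ring itself or from the larger number of heavy atoms, which an ethyl group, a cyclopropyl ring or an amine on this carbon could help to separate.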